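From piperidin-4-yl to cyclopentyl on the shared core

The compounds below may be only part of what the source reports. "The series", "measured", "known", "first", "only" and "open" are said of these compounds alone.

In a functional assay on HCT-116 cells (Homo sapiens) for cytotoxicity, with a stated time of 48 h (a lower number here means a stronger inhibitor of growth, a higher number a weaker inhibitor of growth), compound 1 `Cc1cc(-c2cc(N3C[C@H](O)[C@@H](O)C3)ccc2O)nc(N)n1` gives 400 nM with methyl on the core. Compound 2 `Nc1nc(-c2cc(N3C[C@H](O)[C@@H](O)C3)ccc2O)cc(C2CCCCCC2)n1` gives 300 nM with cycloheptyl there, and the two read alike: a 1.3-fold lower number from compound 1 to compound 2 (0.12 log units; within the scatter) between them.

Compound 3 `Nc1nc(-c2cc(N3C[C@H](O)[C@@H](O)C3)ccc2O)cc(C2CCNCC2)n1` carries piperidin-4-yl and reads > 10000 nM in this assay as a limit, not a number. Compound 3 thus stands at the limit of > 10000 nM in this assay, at which 1 of the 3 values shown sits, in this small set.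

Compound 4 `Nc1nc(-c2cc(N3C[C@H](O)[C@@H](O)C3)ccc2O)cc(C2CCCC2)n1` is next, with cyclopentyl in place of piperidin-4-yl on an aromatic carbon as the difference: cyclopentyl in place of piperidin-4-yl on an aromatic carbon. Among the compounds with values here, two measured steps bear on it, an at least 25-fold higher number from compound 1 to compound 3 (1.39 log units; beyond the scatter) and an at least 33-fold higher number from compound 2 to compound 3 (1.52 log units; beyond the scatter), and both are large. Compound 1 and compound 2 lack piperidin-4-yl and sit close together despite their different groups, so a large step towards a lower number is expected in this assay for this change. The expected step is an at least 28-fold lower number from compound 3 to compound 4 (1.45 log units; beyond the scatter) and rests on the limit of compound 3. The estimate for compound 4 is 350 nM with an expected range of 130 nM to 900 nM.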

Compound 4, concentration for 50% growth inhibition: 400 nM
For compound 4 the middle estimate is 1.1-fold (0.06 log units) below the measured one, and the stated range covers the measured number.
By their numbers in this assay, from the lowest: compounds 2, 1 and 4 (each within the scatter of the next). At a limit, above all of these: compound 3.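

In this assay, cyclopentyl in place of piperidin-4-yl gives an at least 25-fold lower number from compound 3 to compound 4 (1.39 log units; beyond the scatter), so a non-aromatic ring at this position is compatible with growth inhibition. The all-carbon groups read alike, with a 1.3-fold higher number from compound 2 to compound 4 (0.12 log units; within the scatter) and no change at the digits printed from compound 1 to compound 4 (within the scatter); across methyl, cyclopentyl and cycloheptyl, the printed values show no dependence on the group, and only compound 3, with piperidin-4-yl, stands apart. The step from compound 3 is a bound rather than a measured size, because the value of compound 3 is a limit and not a number: the limit of > 10000 nM in this assay, at which 1 of the 4 values shown sits.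

This change alters ring size as well as removing the ring nitrogen, so the shift cannot be assigned to either alone. Cyclohexyl, tetrahydropyran-4-yl or a piperidin-4-yl bearing an acetyl group on its nitrogen would separate these possibilities.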